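This account rests on a few compounds, and the source may have more. Where it says the series, first, only, none or still open, it means among the compounds named here.

Compound 1 `COCOc1cc(/C=C/C(=O)OCC(=O)Nc2ccc(Cl)cc2)ccc1OCc1ccccc1`: > 200000 nM (a limit)
Compound 2 `COc1ccc(NC(=O)COC(=O)/C=C/c2cc(OC)c(OCc3ccc(Cl)c(Cl)c3)c(OC)c2)cc1`: > 200000 nM (a limit)

In a functional assay on PC-3 cells (Homo sapiens) for cytotoxicity, read by MTT assay, with a stated time of 72 h (on this read-out lower numbers stand for stronger inhibition and higher numbers for weaker inhibition), compound 1 gives no number, only (the limit of > 200000 nM in this assay, at which 2 of the 2 values shown sit). Compound 2 likewise stops at the same limit of this assay. Within the data shown here, no two measured compounds differ in one place, so no step size is known from measurement. Compound 3 `COCOc1cc(/C=C/C(=O)OCC(=O)NCc2ccco2)ccc1OCc1ccccc1` differs from compound 1 by (furan-2-yl)methyl in place of 4-chlorophenyl on an amide-type nitrogen. With both measured compounds at the limit, the expected step from compound 1 to compound 3 is none beyond the scatter, a number no higher from compound 1 to compound 3 (the limit leaves the size open). Compound 3 is therefore estimated at 200000 nM, with a range from 60000 nM to 400000 nM, and most likely again reported only as a limit.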

Compound 3, half-maximal inhibitory concentration: > 200000 nM
Compound 3: only a limit was reported (the forecaster's own chance of this, stated with the estimate: 80%); the middle value sits exactly at the limit.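

No step can be read between compound 1 and compound 3 because both stop at the same limit: the limit of > 200000 nM in this assay, at which 3 of the 3 values shown sit.

Whether (furan-2-yl)methyl in place of 4-chlorophenyl changes the activity at all, and how strongly any of these compounds acts in this assay, stays open.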